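A few compounds are considered here, and "the series" means these few. Any claim that something is new, unique, unknown or untested is made for them only; others in the source may bear on it.

In a functional assay on MCF7 cells (Homo sapiens) for antiproliferative activity, with a stated time of 5 days (on this read-out lower numbers stand for stronger inhibition and higher numbers for weaker inhibition), compound 1 `CCCCc1ccc2[nH]c(-c3ccc(C(F)(F)F)cc3)c(/C=N/NC(=O)c3ccc(Cl)cc3)c2c1` gives 1060 nM, compound 2 `CCCCc1ccc2[nH]c(-c3ccc(C(F)(F)F)cc3)c(/C=N/NC(=O)c3ccc([N+](=O)[O-])cc3)c2c1` gives 6340 nM, and compound 3 `CCCCc1ccc2[nH]c(-c3ccc(OC)cc3)c(/C=N/NC(=O)c3cccnc3)c2c1` gives 75 nM, the lowest number of the three. Compound 4 `CCCCc1ccc2[nH]c(-c3ccc(C(F)(F)F)cc3)c(/C=N/NC(=O)c3cccnc3)c2c1` differs from compound 3 in one place: trifluoromethyl in place of methoxy on an aromatic carbon. This puts trifluoromethyl in place of methoxy on an aromatic carbon, para to a large group.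

Among the compounds with values here, the only measured step, a 6.0-fold higher number from compound 1 to compound 2 (0.78 log units; beyond the scatter), is nitro in place of chloro on an aromatic carbon, so it does not measure this change directly. The closest evidence comes from the two compounds that carry the 4-(trifluoromethyl)phenyl group. Compound 1 at 1060 nM and compound 2 at 6340 nM both stand higher than compound 3, although each also differs from it in a second place. A clear move towards a higher number is therefore expected in this assay, but probably not the whole gap. The expected change is a 6.0-fold higher number from compound 3 to compound 4 (0.78 log units; beyond the scatter). For compound 4 the estimate is 450 nM, with an expected range from 120 nM to 2000 nM.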

Compound 4, half-maximal inhibitory concentration: 260 nM
Estimate against measurement, compound 4: 1.7-fold (0.24 log units) above, and the stated range covers the measured number.
By their numbers in this assay, from the lowest: compound 3; then compound 4; then compound 1; then compound 2.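

In this assay, within the data shown here, a 3.5-fold higher number from compound 3 to compound 4 (0.54 log units; beyond the scatter), which is the first direct measure of trifluoromethyl in place of methoxy at this position, para to a large group, and the 4-methoxyphenyl compound keeps the lower number. With 4-(trifluoromethyl)phenyl held fixed, the group on the carbonyl carbon also matters: pyridin-3-yl in place of 4-nitrophenyl gives a 24-fold lower number from compound 2 to compound 4 (1.39 log units; beyond the scatter), and pyridin-3-yl in place of 4-chlorophenyl gives a 4.1-fold lower number from compound 1 to compound 4 (0.61 log units; beyond the scatter), so this second site can move the number as much as the first or more. No measurement shown here explains why either site shifts the number.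

On these data alone, only methoxy and trifluoromethyl appear at this position, so it remains open how an amine or an ethoxy group would compare there. As far as these compounds go, it is also open whether the step between these two groups keeps its size when the group on the carbonyl carbon is not pyridin-3-yl.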